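A few compounds are considered here, and "the series" means these few. Any claim that something is new, unique, unknown or untested is made for them only; others in the source may bear on it.

Measured compounds:
- compound 1 `O=C(NC(=S)Nc1ccc(Oc2ccccc2)cc1)c1ccccc1`, in an assay for inhibition of epoxide hydrolase 1 (Homo sapiens), read by fluorescence, using microsomes (a higher number here means a weaker inhibitor, a lower number a stronger inhibitor), compound 1 gives 2100 nM
- compound 2 `COc1cc([N+](=O)[O-])ccc1NC(=S)NC(=O)c1ccccc1`, in this assay compound 2 gives 1650 nM

Compound 1 holds the highest of the two numbers, but compound 2 sits within the scatter of it, so the two read as equivalent on the evidence at hand. Within the data shown here, no pair here differs in a single place, so there is no measured step to lean on.

Compound 3 `CC(=O)NC(=S)Nc1ccc(Oc2ccccc2)cc1` is the next point to be measured. Relative to compound 1, the change is methyl in place of phenyl on a carbonyl carbon, in words methyl in place of phenyl on a carbonyl carbon, or benzoyl to acetyl when read one bond further out. Among the measured compounds shown here, with no comparable step recorded, the size is uncertain; the expectation is a modest move toward a weaker inhibitor, at the edge of or somewhat beyond the scatter. Compound 3 is therefore estimated at 4000 nM, with a range from 1500 nM to 12000 nM, the expected step being a 1.9-fold higher number from compound 1 to compound 3 (0.28 log units; within the scatter).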

Compound 3, half-maximal inhibitory concentration: 3700 nM
Beside the measured number, compound 3's estimate is 1.1-fold (0.03 log units) above it; the measured number falls inside the stated range.
By their numbers in this assay, from the lowest: compounds 2, 1 and 3 (each within the scatter of the next, the first and the last beyond it).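

In this assay, among these compounds, the first measured step at this position, methyl in place of phenyl on a carbonyl carbon, reads a 1.8-fold higher number from compound 1 to compound 3 (0.25 log units; within the scatter). Benzoyl to acetyl therefore removes one six-membered aromatic ring of carbon only, and compound 1 and compound 3 still read as equivalent on this evidence. The phenyl on this carbonyl carbon is thus not needed to keep the number in this range on the core of compound 1, though no evidence at hand bears on why the two compounds read alike.

As far as these compounds go, it remains open whether a longer chain such as n-butyl, a saturated ring such as cyclohexyl, or an amine on this carbonyl carbon would move the number beyond the scatter. This reading rests on a single pair, so whether the same change behaves alike on another core is also unsettled.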